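Inverting one stereocentre in a piperazine amide series

The source may report more compounds than this note shows. Statements on the series, on what has been measured and on what is new or still open speak of the compounds shown alone.

Measured compounds:
- Compound 1, `CNCC(=O)N1CCN(CCCOc2ccc(C(=O)C3CC3)cc2)CC1`: 79400 nM
- Compound 2, `CCCCCC(=O)c1ccc(OCCCN2CCN(C(=O)[C@@H](C)NC(=O)OC(C)(C)C)CC2)cc1`: 10700 nM
- Compound 3, `CCCCCC(=O)c1ccc(OCCCN2CCN(C(=O)[C@H](CC(C)C)NC(=O)OC(C)(C)C)CC2)cc1`: 3470 nM

Of the compounds shown here, three have been measured in an assay for binding affinity to histamine H2 receptor (Homo sapiens); on this read-out higher numbers stand for weaker inhibition and lower numbers for stronger inhibition. They share a core in which a ketone-bearing aromatic ring is linked through a short ether chain to a piperazine, and differ in the amide attached to that piperazine. Compound 1 carries the smallest amide and gives 79400 nM. Compound 2 carries a protected amino acid amide and gives 10700 nM. Compound 3, with a larger protected amino acid amide, gives 3470 nM, the lowest number of the three; the gap to compound 2 and the larger gap to compound 1 both lie beyond the usual scatter.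

Compound 4, `CCCCCC(=O)c1ccc(OCCCN2CCN(C(=O)[C@@H](CC(C)C)NC(=O)OC(C)(C)C)CC2)cc1`, has not yet been measured. It is the mirror counterpart of compound 3 at a single point: the two compounds have the same atoms and bonds and differ only in configuration as drawn: 1 of 1 stereo elements differ; a stereocentre at a saturated chain carbon is drawn S in compound 3 and R in compound 4. Within the data shown here, no measured pair in this set differs only in configuration, so there is no direct precedent here for the size of such a step. Inverting the configuration at a stereocentre often weakens binding in this kind of assay, though not always. In this assay a modest step toward a higher number is expected, a 2.3-fold higher number from compound 3 to compound 4 (0.36 log units; beyond the scatter). For compound 4 the estimate is 8000 nM, with a range from 2500 nM to 25000 nM.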

Compound 4, inhibition constant: 4470 nM
Beside the measured number, compound 4's estimate is 1.8-fold (0.25 log units) above it, and the stated range covers the measured number.
By their numbers in this assay, from the lowest: compounds 3 and 4 (each within the scatter of the next); then compound 2; then compound 1.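

In this assay, inverting this stereocentre gives a 1.3-fold higher number from compound 3 to compound 4 (0.11 log units; within the scatter), so the two mirror forms cannot be told apart on this read-out, and the configuration drawn at this carbon shows no measurable effect here. Among these compounds, this is a clean test of that single feature, and the earlier compounds offered no such pair: the fact that compounds 3 and 4 differ only in the configuration as drawn. The change at the same carbon does register, with isopropyl in place of hydrogen on the saturated chain carbon giving a 2.4-fold lower number from compound 2 to compound 4 (0.38 log units; beyond the scatter), so in this small set what the carbon carries shifts the number by a modest but real amount, while its drawn configuration does not.

From the compounds shown here alone, this rests on one mirror pair and one change of group, so it remains open whether the configuration would still make so little difference with a phenyl ring or a carboxylic acid in place of that isopropyl. Going by these compounds, it is also open whether the same holds once the protecting carbamate gives way to a free amine, or with the mirror form of compound 2, whose smaller amide may respond differently to inversion.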